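The compounds below may be only part of what the source reports. "The series", "measured", "known", "first", "only" and "open" are said of these compounds alone.

Measured so far:
Compound 1 `NC(=O)[C@@H]1CCCN1C(=O)CCCCCN1CCN(c2ccc(F)cc2)CC1`: in an assay on HEK293 cells for displacement of a labelled ligand from 5-hydroxytryptamine receptor 7 (Homo sapiens), with a stated time of 1 h (on this read-out lower numbers stand for stronger inhibition and higher numbers for weaker inhibition), compound 1 gives 1190 nM.
Compound 2 `COc1ccccc1N1CCN(CCCCCC(=O)N2Cc3ccccc3C[C@H]2C(N)=O)CC1`: in this assay compound 2 gives 302 nM.
Compound 3 `NC(=O)[C@@H]1Cc2ccccc2CN1C(=O)CCCCCN1CCN(c2ccccc2Cl)CC1`: in this assay compound 3 gives 393 nM.

Among these three numbers compound 3 stands second highest. Its nearest neighbour is compound 2, within the scatter; compound 1 lies furthest away, beyond the scatter.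

Compound 4 `NC(=O)[C@@H]1Cc2ccccc2CN1C(=O)CCCCCN1CCN(c2cccc(Cl)c2Cl)CC1` differs from compound 3 in one place: chloro in place of hydrogen on an aromatic carbon. The new chloro sits on an aromatic carbon of a six-membered aromatic ring of carbon only, ortho to a chloro group and meta to a large group; seen one bond further out, 2-chlorophenyl becomes 2,3-dichlorophenyl.

Going by the values given here, only one measured step touches this ring, the exchange of methoxy for chloro, a 1.3-fold higher number from compound 2 to compound 3 (0.11 log units; within the scatter), and it stayed within the scatter. Among the compounds with values here, no measured step adds a second group to this ring, so the direction is open. Compound 4 is therefore expected to give about 350 nM, with a range from 120 nM to 1000 nM. This estimate amounts to a 1.1-fold lower number from compound 3 to compound 4 (0.05 log units; within the scatter), no step beyond the scatter.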

Compound 4, inhibition constant: 95 nM
Compound 4: middle estimate off by 3.7-fold (0.57 log units), on the high side, and the stated range ends above it.
By their numbers in this assay, from the lowest: compound 4; then compounds 2 and 3 (each within the scatter of the next); then compound 1.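

In this assay, adding a second chloro, so that 2-chlorophenyl becomes 2,3-dichlorophenyl, gives a 4.1-fold lower number from compound 3 to compound 4 (0.62 log units; beyond the scatter) and thus a step beyond the scatter. Going by these compounds alone, this shows that the number responds to a change at this carbon, ortho to a chloro group and meta to a large group, whereas the one earlier change on this ring, a 1.3-fold higher number from compound 2 to compound 3 (0.11 log units; within the scatter), stayed within the scatter. Replacing 2-methoxyphenyl outright with 2,3-dichlorophenyl points the same way, with a 3.2-fold lower number from compound 2 to compound 4 (0.50 log units; beyond the scatter) again beyond the scatter.

No available evidence explains why the added chloro lowers the number. On these data alone, it remains open whether a bromo or a methyl group on this same carbon would lower the number as far as chloro does.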